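Changing one aromatic ring in a cell-growth inhibitor

The source may report more compounds than this note shows. Statements on the series, on what has been measured and on what is new or still open speak of the compounds shown alone.

Compound 1 `CN(C)CCn1cnnc1-c1cc(Oc2ccc(NC(=O)N/N=C/c3ccc(F)cc3F)cc2F)ccn1`: 810 nM
Compound 2 `Cn1cnnc1-c1cc(Oc2ccc(NC(=O)N/N=C/c3ccccc3)cc2F)ccn1`: 7610 nM

In a functional assay on MKN-45 cells (Homo sapiens) for cytotoxicity, read by MTT assay, with a stated time of 72 h (a lower number here means a stronger inhibitor, a higher number a weaker inhibitor), compound 1 gives 810 nM, the lowest of the two numbers. Compound 2 gives 7610 nM in this assay, a higher number that lies beyond the usual scatter. Within the data shown here, compound 2 differs from compound 1 in more than one place, so the two values together say only that compound 1 is the stronger inhibitor of the pair; they do not tell which part of the structure carries the difference.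

Compound 3 `Cc1cc(/C=N/NC(=O)Nc2ccc(Oc3ccnc(-c4nncn4CCN(C)C)c3)c(F)c2)cc(C)c1O` has not yet been measured. Relative to compound 1 it changes only one group: 4-hydroxy-3,5-dimethylphenyl in place of 2,4-difluorophenyl on a carbon with a double bond to nitrogen. Among the measured compounds shown here, no measured pair shows the effect of such a change, so its direction is unknown from these data alone. The step of a 1.5-fold higher number from compound 1 to compound 3 (0.17 log units; within the scatter) is expected to be modest, with no clear direction beyond the scatter. Compound 3 is therefore estimated at 1200 nM in this assay, within a range from 300 nM to 5000 nM.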

Compound 3, half-maximal inhibitory concentration: 1510 nM
Beside the measured number, compound 3's estimate is 1.3-fold (0.10 log units) below it; measured number inside the range.
By their numbers in this assay, from the lowest: compounds 1 and 3 (each within the scatter of the next); then compound 2.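

In this assay, putting 4-hydroxy-3,5-dimethylphenyl in place of 2,4-difluorophenyl on a carbon with a double bond to nitrogen gives a 1.9-fold higher number from compound 1 to compound 3 (0.27 log units; within the scatter), so the two compounds cannot be told apart here. Among these compounds, this is the first pair that differs in one place only, and it shows that, with the rest of compound 1 kept, these two quite different substituted phenyl rings give values within the usual scatter. Nothing measured here explains why the numbers lie so close.

One pair cannot show how far this position stays so undemanding: a ring carrying a carboxylic acid or a primary amine could behave differently. Which of its differences from compound 1 accounts for the higher number of compound 2 also remains open.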